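Amino in place of bromo: an untested step

A few compounds are considered here, and "the series" means these few. Any claim that something is new, unique, unknown or untested is made for them only; others in the source may bear on it.

In a functional assay on PC-3 cells (Homo sapiens) for antiproliferative activity, read by MTT assay, with a stated time of 48 h (a higher number here means a weaker inhibitor, a lower number a stronger inhibitor), compound 1 (`COc1ccc(CN(C(=O)CSc2nc3ccccc3s2)c2cc(OC)c(OC)c(OC)c2)cc1`) gives 8460 nM and compound 2 (`COc1ccc(CN(C(=O)CSc2nc3ccccc3s2)c2cc(OC)c(OC)c(OC)c2)cc1Br`) gives 16000 nM as its half-maximal inhibitory concentration. Compound 2 has only compound 1 for comparison, and the two values lie within the scatter of each other. Compound 3 (`COc1ccc(CN(C(=O)CSc2nc3ccccc3s2)c2cc(OC)c(OC)c(OC)c2)cc1N`) keeps the rest of compound 2 and alters one group: amino in place of bromo on an aromatic carbon, ortho to a methoxy group and meta to a large group (amino in place of bromo on an aromatic carbon). For the measured compounds named here, only one measured step bears on this carbon. Bromo in place of hydrogen there gave a 1.9-fold higher number from compound 1 to compound 2 (0.28 log units; within the scatter) and this small step is the sole guide. Going by the values given here, no compound with an amino group has yet been measured, so the data offer only weak support for any direction. With bromo gone, a value near that of compound 1 seems a reasonable expectation. The step expected is a 1.6-fold lower number from compound 2 to compound 3 (0.20 log units; within the scatter) and so nothing beyond the scatter is foreseen. Compound 3 is estimated at 10000 nM in this assay with an expected range from 3000 nM to 25000 nM as its likely span.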

Compound 3, half-maximal inhibitory concentration: 7510 nM
Compound 3: the middle estimate sits 1.3-fold (0.12 log units) above what was measured; measured number inside the range.
By their numbers in this assay, from the lowest: compounds 3, 1 and 2 (each within the scatter of the next, the first and the last beyond it).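

In this assay the carbon ortho to a methoxy group now shows its first step beyond the scatter: amino in place of bromo gives a 2.1-fold lower number from compound 2 to compound 3 (0.33 log units; beyond the scatter), a modest change that shows bromo and amino can be told apart at this position. Amino in place of hydrogen on the same carbon gives a 1.1-fold lower number from compound 1 to compound 3 (0.05 log units; within the scatter), so this comparison shows no readable change, and the amino group is tolerated here with the number staying within the scatter of the hydrogen-bearing compound. Nothing measured alongside these values accounts for the difference between bromo and amino.

Going by these compounds, whether a hydroxyl group, an acetamide or a fluoro group on this carbon would move the number beyond the scatter of compound 1 remains open, so the range of groups that this position can distinguish is still unknown. Also open, on these data alone, is whether amino in place of bromo would give a similar step if the methoxy group on the same ring were replaced by an ethoxy group or a hydroxyl group.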